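A Trichloromethyl Swap and Liver Fraction Stability

A few compounds are considered here, and "the series" means these few. Any claim that something is new, unique, unknown or untested is made for them only; others in the source may bear on it.

Compound 1 `C[C@@H]1CN(C(=O)c2nc(Nc3cc(C4CC4)[nH]n3)c3cc(Cl)ccc3n2)CCN1C(=O)OCc1ccccc1`: 45.6%
Compound 2 `CCCCCOC(=O)N1CCN(C(=O)c2nc(Nc3cc(C4CC4)[nH]n3)c3cc(Cl)ccc3n2)C[C@H]1C`: 63.9%

Among the compounds with values here, in an ADME assay on S9 fraction from liver (Rattus norvegicus), read by LC-MS, with a stated time of 60 min, at 37 degrees C (on this read-out higher numbers stand for a more stable compound and lower numbers for a less stable compound), compound 2 gives 63.9%, the higher of the two numbers measured so far. Compound 3 `C[C@@H]1CN(C(=O)c2nc(Nc3cc(C4CC4)[nH]n3)c3cc(Cl)ccc3n2)CCN1C(=O)OCC(Cl)(Cl)Cl` has not yet been measured. It carries trichloromethyl in place of butyl on a saturated chain carbon bound to an oxygen next to a carbonyl group.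

Within the data shown here, only one measured step changes this same place: a number 18.3 percentage points higher from compound 1 to compound 2 (beyond the scatter). That modest step, beyond the scatter, shows that the number in this assay can move with the group placed here. Among the measured compounds shown here, no measured compound carries trichloromethyl, so the direction remains uncertain and the range must stay wide. The expected move is small and downward, probably within the scatter: a number 5.9 percentage points lower from compound 2 to compound 3 (within the scatter). For compound 3 the estimate is 58%, with an expected range from 38% to 78%.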

Compound 3, percent of the compound remaining: 78.9%
Estimate against measurement, compound 3: 20.9 percentage points below; the whole stated range lies below it.
By their numbers in this assay, from the lowest: compound 1; then compound 2; then compound 3.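

In this assay this place now gives three separate levels rather than two: swapping butyl for trichloromethyl gives a number 15 percentage points higher from compound 2 to compound 3 (beyond the scatter) on top of the earlier rise, and swapping phenyl for trichloromethyl gives a number 33.3 percentage points higher from compound 1 to compound 3 (beyond the scatter) as the largest step seen here. The order from lowest to highest runs phenyl, butyl, trichloromethyl, and each step between these compounds lies beyond the scatter. Butyl and trichloromethyl both count 4 heavy atoms, so that count alone does not set the number on this read-out.

On these data alone, it remains open how a 2,2,2-trifluoroethyl group or a longer chain would rank in this same place. Nothing measured here explains the rise.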